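Cyclopropane amides: cyclohexyl to pyrimidinyl on the small ring

A few compounds are considered here, and "the series" means these few. Any claim that something is new, unique, unknown or untested is made for them only; others in the source may bear on it.

Measured so far in a functional assay for agonist activity at G protein-coupled receptor 88 (Homo sapiens), read by HTRF and cAMP accumulation; on this read-out lower numbers stand for an effect already at smaller amounts and higher numbers for an effect only at larger amounts of compound:
compound 1, `CC[C@H](C)[C@H](N)CN(C(=O)[C@@H]1C[C@H]1c1cccc(Cl)c1)c1ccc(-c2ccccc2)cc1`: 2200 nM
compound 2, `CC[C@H](C)[C@H](N)CN(C(=O)[C@@H]1C[C@H]1c1cccc(C#N)c1)c1ccc(-c2ccccc2)cc1`: 1600 nM
compound 3, `CC[C@H](C)[C@H](N)CN(C(=O)[C@@H]1C[C@H]1C1CCCCC1)c1ccc(-c2ccccc2)cc1`: > 25000 nM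

For compound 3 the value is a limit of the assay, not a number (the limit of > 25000 nM in this assay, at which 1 of the 3 values shown sits). Compound 3 therefore stands at the weak end of the three compounds shown, apart from compounds 1 and 2 by steps that are beyond the scatter. Compounds 1 and 2 sit within the scatter of each other, a 1.4-fold lower number from compound 1 to compound 2 (0.14 log units; within the scatter), so the substituent on the aromatic ring has not moved the read-out much here. What does move it is the ring on the saturated ring carbon: an at least 11-fold higher number from compound 1 to compound 3 (1.05 log units; beyond the scatter) and an at least 15-fold higher number from compound 2 to compound 3 (1.19 log units; beyond the scatter) are both large losses when the aromatic ring gives way to cyclohexyl.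

Compound 4, `CC[C@H](C)[C@H](N)CN(C(=O)[C@@H]1C[C@H]1c1ncccn1)c1ccc(-c2ccccc2)cc1`, differs from compound 3 by pyrimidin-2-yl in place of cyclohexyl on a saturated ring carbon. The two large measured steps both bear on this change, since they describe the reverse move, from an aromatic ring to cyclohexyl. Going by these compounds, an aromatic ring returns in compound 4, so a large step back toward smaller numbers in this assay is expected, an at least 5.0-fold lower number from compound 3 to compound 4 (0.69 log units; beyond the scatter), though a ring with two hetero atoms is untested and the size is uncertain. Compound 4 is estimated at 5000 nM, with a range from 1500 nM to 25000 nM.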

Compound 4, half-maximal effective concentration: 130 nM
The estimate for compound 4 lay 38-fold (1.59 log units) above the measured number; the whole stated range lies above it.
By their numbers in this assay, from the lowest: compound 4; then compounds 2 and 1 (each within the scatter of the next). At a limit, above all of these: compound 3.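

In this assay the value of compound 3 is a limit of the assay and not a number: the limit of > 25000 nM in this assay, at which 1 of the 4 values shown sits.

Pyrimidin-2-yl in place of cyclohexyl on the saturated ring carbon still reads as an at least 190-fold lower number from compound 3 to compound 4 (2.28 log units; beyond the scatter), so this place tolerates a ring with 2 hetero atoms and answers to it strongly. The new information lies in the comparison among aromatic rings: the earlier pair showed only that cyano in place of chloro stayed within the scatter, whereas pyrimidin-2-yl gives a 12-fold lower number from compound 2 to compound 4 (1.09 log units; beyond the scatter) and a 17-fold lower number from compound 1 to compound 4 (1.23 log units; beyond the scatter), so the presence of an aromatic ring at this place does not by itself set the value.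

Open, going by these compounds, is how pyridin-2-yl or unsubstituted phenyl would read at this place, and with them whether one ring nitrogen would serve as well as two. Also open, on these data alone, is whether an amine or a methoxy group on the pyrimidin-2-yl ring would hold what compound 4 gives, 130 nM.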